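Swapping Carbamoyl for Trifluoromethyl: What to Expect

The source may hold more compounds than are shown below. What is called first, only, known or untested is meant among the compounds shown, and "the series" means these compounds.

Measured so far in an assay on isolated protein for inhibition of 2-Hydroxyacid oxidase 2 (Homo sapiens), tested at 1 uM; a lower number here means a weaker effect, a higher number a stronger effect of the compound at the concentration tested:
- compound 1, `Cc1n[nH]c(C(=O)O)c1Cc1ccc(C(F)(F)F)cc1`, gives 9%
- compound 2, `Cc1n[nH]c(C(=O)O)c1Cc1cccc(-c2ccc(C(N)=O)cc2)c1`, gives 18%
- compound 3, `Cc1n[nH]c(C(=O)O)c1Cc1ccc(C(N)=O)cc1`, gives 0%

Compound 1 differs from compound 3 by one change, (trifluoromethyl in place of carbamoyl on an aromatic carbon), and the step was a number 9 percentage points higher from compound 3 to compound 1 (within the scatter). Compound 4, `Cc1n[nH]c(C(=O)O)c1Cc1cccc(-c2ccc(C(F)(F)F)cc2)c1`, has not yet been measured; it arises from compound 2 by the same change, (trifluoromethyl in place of carbamoyl on an aromatic carbon), at the same kind of place. The difference between the core of compound 2 and the core of compound 3 is not broken down here. Because the earlier step of a number 9 percentage points higher from compound 3 to compound 1 (within the scatter) was small, a step of similar size is expected from compound 2 to compound 4, namely a number 9 percentage points higher from compound 2 to compound 4 (within the scatter), in this assay. Compound 4 is therefore estimated to give about 27%, likely between 10% and 45%.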

Compound 4, a percentage reported as inhibition, at one concentration (the size of the read-out at that concentration, not a potency): 8%
For compound 4 the middle estimate is 19 percentage points above the measured one, and the stated range ends above it.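

In this assay, trifluoromethyl in place of carbamoyl gives a number 10 percentage points lower from compound 2 to compound 4 (within the scatter) on the core of compound 2. Set beside the earlier step, the same change does not carry over with the same result from one core to the other: the same change on two cores in this assay, a number 9 percentage points higher (within the scatter) from compound 3 to compound 1 and a number 10 percentage points lower (within the scatter) from compound 2 to compound 4, 19 percentage points apart, beyond the scatter of two such steps. This does not show why the two steps part, and since each step alone lies within the scatter, neither one by itself establishes an effect of the change on its own core.

On these data alone, it remains open whether such a gap would recur on further cores. Also open, as far as these compounds go, is how another group in the same place, such as a nitrile or an amine, would read on these two cores.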